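Exchanging the Thiazolyl Group on Compound 3

The compounds below may be only part of what the source reports. "The series", "measured", "known", "first", "only" and "open" are said of these compounds alone.

In a functional assay on DLD-1 cells (Homo sapiens) for antiproliferative activity (on this read-out higher numbers stand for weaker inhibition and lower numbers for stronger inhibition), compound 3 `CNC(=O)c1sc(N2N=C(c3ccc(C)cc3)CC2c2cc3cc(OC)ccc3nc2Cl)nc1C` gives 38 nM. Compound 1 `CCONC(=O)c1sc(N2N=C(c3ccc(C)cc3)CC2c2cc3cc(OC)ccc3nc2Cl)nc1C` gives 38 nM, and compound 2 `COc1ccc2nc(Cl)c(C3CC(c4ccc(C)cc4)=NN3c3nc(-c4ccc(Cl)cc4)cs3)cc2c1` gives 38 nM, so compound 3 stands level with both. The next analogue, compound 4 `COc1ccc2nc(Cl)c(C3CC(c4ccc(C)cc4)=NN3c3nc(-c4ccc(C)cc4)cs3)cc2c1`, carries 4-(4-methylphenyl)-1,3-thiazol-2-yl in place of 4-methyl-5-(methylcarbamoyl)-1,3-thiazol-2-yl on an amine nitrogen in a ring. Two measured exchanges of groups on that same nitrogen bear on this change, and they show no change at the digits printed from compound 1 to compound 2 (within the scatter) and no change at the digits printed from compound 2 to compound 3 (within the scatter). No step beyond the scatter is therefore expected in this assay. The expected outcome is a 1.1-fold higher number from compound 3 to compound 4 (0.02 log units; within the scatter). The estimate for compound 4 is 40 nM, with an expected range of 15 nM to 100 nM.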

Compound 4, half-maximal inhibitory concentration: 38 nM
Beside the measured number, compound 4's estimate is 1.1-fold (0.02 log units) above it; the range from low to high includes it.
By their numbers in this assay, from the lowest: compounds 1, 2, 3 and 4 (each within the scatter of the next).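

In this assay the step to the 4-(4-methylphenyl)-1,3-thiazol-2-yl group gives no change at the digits printed from compound 3 to compound 4 (within the scatter) even though this group has no hydrogen-bond donor and the group it replaces has one. The step from the ethoxycarbamoyl analogue likewise gives no change at the digits printed from compound 1 to compound 4 (within the scatter) and adds a second such comparison. Methyl in place of chloro on an aromatic carbon of the phenyl group gives no change at the digits printed from compound 2 to compound 4 (within the scatter) as the first exchange shown at that aromatic carbon. No evidence here accounts for these flat results. Still open, on these data alone, is whether a carboxylic acid or an amine on that phenyl ring, or a plain phenyl group in place of the thiazole on the ring nitrogen, would leave the number equally unmoved.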